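The source may report more compounds than this note shows. Statements on the series, on what has been measured and on what is new or still open speak of the compounds shown alone.

Measured so far in a physicochemical assay for lipophilicity, using the shake flask method, with a stated time of 4 h, at pH 7.4; a lower number here means a more polar compound, a higher number a more lipophilic compound:
compound 1, `O=C1OC(C(O)CO)C(OCCCCCCO[N+](=O)[O-])=C1O`: 0.76
compound 2, `NC(=O)c1c(COC2=C(O)C(=O)OC2C(O)CO)no[n+]1[O-]`: -1.44
compound 3, `O=C1OC(C(O)CO)C(OCCCOc2no[n+]([O-])c2S(=O)(=O)c2ccccc2)=C1O`: 0.98

Compound 3 gives the highest of the three numbers. Compound 1 sits close to it, within the usual scatter, so no order can be read between compound 3 and compound 1; compound 2 sits far below, beyond the scatter.

Compound 4 is `O=C1OC(C(O)CO)C(OCCCOc2no[n+]([O-])c2-c2ccccc2)=C1O` and has not yet been measured. Among the compounds with values here, it differs from compound 3 in one place: phenyl in place of phenylsulfonyl on an aromatic carbon No comparable step exists among the measured compounds, so the direction and size of the step rest on the structural change alone. In this assay the step of a number 0.92 log units higher from compound 3 to compound 4 (beyond the scatter) is expected, upward and beyond the scatter. Compound 4 is estimated at 1.9, within a range of 1.3 to 2.5.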

Compound 4, distribution coefficient: 1.13
Beside the measured number, compound 4's estimate is 0.77 log units above it, outside the stated range (below it).
By their numbers in this assay, from the lowest: compound 2; then compounds 1, 3 and 4 (each within the scatter of the next, the first and the last beyond it).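

In this assay, phenyl in place of phenylsulfonyl on this aromatic carbon gives a number 0.15 log units higher from compound 3 to compound 4 (within the scatter) as the first step read at this position. The two groups are therefore not separated here, and no order can be drawn between the two compounds. Nothing available accounts for this outcome.

From the compounds shown here alone, whether an amine or a carboxylic acid on this carbon would shift the number beyond the scatter remains open. Also open, going by these compounds, is whether the same exchange would read alike with a longer chain joining this ring to the shared core.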